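Exchanging the Chlorophenyl Amide in a Weak Antiproliferative

The source may report more compounds than this note shows. Statements on the series, on what has been measured and on what is new or still open speak of the compounds shown alone.

Compound 1 `CCN1CCN(c2cc(C)c3cc(NC(=O)c4cccc(Cl)c4)ccc3n2)CC1` gives 17800 nM in a functional assay on SK-BR-3 cells (Homo sapiens) for antiproliferative activity, read by MTT assay, with a stated time of 72 h (on this read-out higher numbers stand for weaker inhibition and lower numbers for stronger inhibition), the highest of the three numbers at hand. Compound 2 `Cc1cc(NCCN(C)C)nc2ccc(NC(=O)c3ccc(Cl)c(Cl)c3)cc12` gives 6670 nM, and compound 3 `Cc1cc(NCCN2CCN(C)CC2)nc2ccc(NC(=O)c3ccc(Cl)c(Cl)c3)cc12` gives 2690 nM; between those two, a 2.5-fold lower number from compound 2 to compound 3 (0.39 log units; beyond the scatter). Compound 4 `CCc1ccc(C(=O)Nc2ccc3nc(N4CCN(CC)CC4)cc(C)c3c2)cc1` differs from compound 1 in one place: 4-ethylphenyl in place of 3-chlorophenyl on a carbonyl carbon. Among the measured compounds shown here, no measured step touches this part of the molecule; the single measured step, from compound 2 to compound 3, sits elsewhere on the shared core and so does not bear on the change at the carbonyl carbon. With nothing to guide a direction, compound 4 is expected to land within the scatter of compound 1, a step of no change at the digits printed from compound 1 to compound 4 (within the scatter). Compound 4 is therefore estimated at 17800 nM, with a range from 6000 nM to 50000 nM.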

Compound 4, half-maximal inhibitory concentration: 9850 nM
Beside the measured number, compound 4's estimate is 1.8-fold (0.26 log units) above it; low and high end bracket the measured number.
By their numbers in this assay, from the lowest: compound 3; then compounds 2, 4 and 1 (each within the scatter of the next, the first and the last beyond it).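

In this assay, the exchange on the carbonyl carbon gives a 1.8-fold lower number from compound 1 to compound 4 (0.26 log units; within the scatter). Among the compounds shown here, this is the first reading at this position, and it shows that 3-chlorophenyl can give way to 4-ethylphenyl with no change beyond the scatter, so the chlorine is not needed to hold this weak activity. Because the group and its ring position change together, the step cannot separate the two.

On these data alone, whether a carboxylic acid, an amine or a longer chain on this ring would move the number stays open. No evidence at hand accounts for this result.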